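Acetyl in Place of Fluoro on the Shared Core

The source may hold more compounds than are shown below. What is called first, only, known or untested is meant among the compounds shown, and "the series" means these compounds.

Compound 2 `Fc1ccc(-c2cn3ccnc3c(-c3ccc4ncn(C5CCCCC5)c4c3)n2)cc1` stands lowest of the two numbers measured: in a functional assay on NCI-H322M cells (Homo sapiens) for inhibition, read by sulforhodamine B assay, with a stated time of 48 h, tested at 10 uM (on this read-out higher numbers stand for more inhibition at the one concentration tested (going by the name of the read-out) and lower numbers for less inhibition), compound 2 gives 0.01%, whereas compound 1 `O=Cc1ccc(-c2cn3ccnc3c(-c3ccc4ncn(C5CCCCC5)c4c3)n2)cc1` gives 11.2%. For the measured compounds named here, the one measured step bears directly on the change at hand, since a number 11.2 percentage points lower from compound 1 to compound 2 (beyond the scatter). Compound 3 `CC(=O)c1ccc(-c2cn3ccnc3c(-c3ccc4ncn(C5CCCCC5)c4c3)n2)cc1` differs from compound 2 by acetyl in place of fluoro on an aromatic carbon; acetyl, like the formyl of compound 1, carries a carbonyl. A step back upward of about the same size is therefore expected, and compound 3 is estimated at 10%, between -5% and 25%, an expected a number 10 percentage points higher from compound 2 to compound 3 (within the scatter).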

Compound 3, a percentage reported as inhibition, at one concentration (the size of the read-out at that concentration, not a potency): 1.19%
Compound 3: the middle estimate sits 8.8 percentage points above what was measured, within the range that was stated.
By their numbers in this assay, from the lowest: compounds 2, 3 and 1 (each within the scatter of the next, the first and the last beyond it).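

Acetyl in place of fluoro gives a number 1.2 percentage points higher from compound 2 to compound 3 (within the scatter), so a carbonyl on this ring does not by itself set a compound apart from the fluoro one. Methyl in place of hydrogen on the carbonyl carbon gives a number 10 percentage points lower from compound 1 to compound 3 (within the scatter), which leaves compound 3 within the scatter of both neighbours, even though those two lie beyond the scatter of each other. Nothing available explains these numbers. Still open, going by these compounds, is whether an amine or a carboxylic acid at this place on the ring would give a number clearly beyond that of compound 1.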